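A few compounds are considered here, and "the series" means these few. Any claim that something is new, unique, unknown or untested is made for them only; others in the source may bear on it.

Three compounds built on one shared core were measured in a physicochemical assay for solubility, read by HPLC, using the shake flask method, measured as kinetic solubility, with a stated time of 2 h, at pH 7.4; a higher number here means a more soluble compound, a lower number a less soluble compound. Compound 1 `Cc1ccc(-c2cnn3c(NCc4ccccn4)cc(C)nc23)cc1` gives < 5000 nM, which is a limit of this assay rather than a number (the limit of < 5000 nM in this assay, at which 1 of the 3 values shown sits). Compound 2 `Cc1cc(NCc2ccccn2)n2ncc(Br)c2n1` gives 89300 nM in this assay. Compound 3 `Cc1cc(NCc2ccccn2)n2ncc(-c3ccn(C)n3)c2n1` gives 188000 nM in this assay, the highest of the two numbers shown, and its nearest neighbour is compound 2, separated by a 2.1-fold higher number from compound 2 to compound 3 (0.32 log units; beyond the scatter). The two remaining steps were larger: an at least 17-fold higher number from compound 1 to compound 2 (1.25 log units; beyond the scatter), and an at least 37-fold higher number from compound 1 to compound 3 (1.57 log units; beyond the scatter).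

Compound 4 `Cc1cc(NCc2ccccn2)n2ncc(-c3ccc(F)cc3C)c2n1` has not yet been measured. It differs from compound 3 in one place: 4-fluoro-2-methylphenyl in place of 1-methyl-1H-pyrazol-3-yl on an aromatic carbon. The measured step that bears most on this is an at least 37-fold higher number from compound 1 to compound 3 (1.57 log units; beyond the scatter), in which a six-membered ring of carbon only gave way to a five-membered ring with two hetero atoms. Compound 4 makes a change of the opposite kind, swapping that five-membered ring back for a six-membered ring of carbon only, so a large fall in this assay is expected, possibly reaching the limit seen for compound 1. Compound 4 is therefore estimated at 8000 nM, with a range from 2000 nM to 40000 nM. The expected step is a 24-fold lower number from compound 3 to compound 4 (1.37 log units; beyond the scatter), beyond the scatter.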

Compound 4, solubility: 42300 nM
Estimate against measurement, compound 4: 5.3-fold (0.72 log units) below; the measured number lies above the stated range.
By their numbers in this assay, from the lowest: compound 4; then compound 2; then compound 3. At a limit, below all of these: compound 1.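

In this assay, a six-membered aromatic ring of carbon only on this aromatic carbon does not by itself bring the number down to the limit: there is a 4.4-fold lower number from compound 3 to compound 4 (0.65 log units; beyond the scatter), a modest fall, and a 2.1-fold lower number from compound 2 to compound 4 (0.32 log units; beyond the scatter), so the 4-fluoro-2-methylphenyl group stays within reach of the much smaller bromo. The two carbon-only rings also part from each other, with an at least 8.4-fold higher number from compound 1 to compound 4 (0.92 log units; beyond the scatter), so at this position what the ring carries matters as well as the kind of ring, and the earlier contrast between carbon-only and hetero-atom rings rested on compound 1 alone. Compound 1 remains a limit and not a number, so the full size of that gap is unknown: the limit of < 5000 nM in this assay, at which 1 of the 4 values shown sits.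

The compounds shown do not separate the part played by the fluoro from that of the methyl within the 4-fluoro-2-methylphenyl group. They also leave open how a pyridine ring, or a phenyl ring carrying an amine or a carboxylic acid, would read on this same aromatic carbon.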